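This account rests on a few compounds, and the source may have more. Where it says the series, first, only, none or still open, it means among the compounds named here.

Among the measured compounds shown here, compound 1 `C/C=C/C=C/C(=O)N(Cc1ccc(OC)c(O)c1)c1cc(OC)c(OC)c(OC)c1` stands lowest among the numbers so far in a functional assay on MGC-803 cells (Homo sapiens) for inhibition, read by MTT assay, with a stated time of 48 h (on this read-out lower numbers stand for stronger inhibition and higher numbers for weaker inhibition), where compound 1 gives 140 nM. The nearest is compound 3 `C/C=C/C(=O)N(Cc1ccc(OC)c(Cl)c1)c1cc(OC)c(OC)c(OC)c1`, which in this assay gives 7100 nM, a gap beyond the usual scatter. Compound 2 `COc1cc(NCc2ccccc2)cc(OC)c1OC` gives only > 80000 nM in this assay, a limit and not a number, the one described as the limit of > 80000 nM in this assay, at which 1 of the 3 values shown sits. Compound 4 `COCC(=O)N(Cc1ccc(OC)c(O)c1)c1cc(OC)c(OC)c(OC)c1` is not yet measured. It differs from compound 1 in one place: methoxymethyl in place of penta-1,3-dien-1-yl on a carbonyl carbon. For the measured compounds named here, no measured pair shows this change, so its size is open; compound 2 sits at its limit and compound 3 far above compound 1, so a step toward a higher number, beyond the scatter, is expected as a 21-fold higher number from compound 1 to compound 4 (1.33 log units; beyond the scatter). Compound 4 is estimated at 3000 nM, between 500 nM and 20000 nM.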

Compound 4, half-maximal inhibitory concentration: 79 nM
The estimate for compound 4 lay 38-fold (1.58 log units) above the measured number; measured number outside the range, below it.
By their numbers in this assay, from the lowest: compounds 4 and 1 (each within the scatter of the next); then compound 3. At a limit, above all of these: compound 2.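

In this assay, the carbonyl carbon on the amide-type nitrogen accepts this exchange with no change beyond the scatter: a 1.8-fold lower number from compound 1 to compound 4 (0.25 log units; within the scatter). The penta-1,3-dien-1-yl group and its double bonds are therefore not required at this position, since methoxymethyl, with fewer heavy atoms and one oxygen, serves in its place. No result shown gives a cause for this step.

From the compounds shown here alone, whether the oxygen of methoxymethyl matters remains open, as a plain propyl chain would test this. Also open, going by these compounds, is how an aminomethyl group, a carboxylic acid or a longer ether chain would fare on this carbonyl carbon.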